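The compounds below may be only part of what the source reports. "The series", "measured", "known", "first", "only" and "open" are said of these compounds alone.

Compound 1 `COc1ccc(-c2c(S(=O)(=O)c3cccc(F)c3)cnc3cc(F)ccc23)cc1` gives 1.89 mL/min in an ADME assay on microsomes from liver (Homo sapiens) for metabolic stability, tested at 2.5 uM; a higher number here means faster removal of the compound, a lower number slower removal. Compound 2 `O=S(=O)(c1cc(F)cc(F)c1)c1cnc2cc(F)ccc2c1-c1cccc(Cl)c1` gives 0.22 mL/min. Compound 3 `COc1ccc(-c2c(S(=O)(=O)c3ccc(C)c(C)c3)cnc3cc(F)ccc23)cc1` gives 4.13 mL/min.

Among these three, compound 3 shows the highest number in this assay, meaning it is removed fastest; compound 1 is the nearest to it and compound 2 sits far lower. Compound 4 `COc1ccc(-c2c(S(=O)(=O)c3cc(F)cc(F)c3)cnc3cc(F)ccc23)cc1` has not yet been measured. It differs from compound 3 in one place: 3,5-difluorophenyl in place of 3,4-dimethylphenyl on a sulfonyl sulfur.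

Going by the values given here, only one measured step touches the same place on the sulfonyl sulfur: a 2.2-fold higher number from compound 1 to compound 3 (0.34 log units; beyond the scatter). That step exchanged a fluorinated phenyl ring for 3,4-dimethylphenyl and raised the number modestly; compound 4 makes the reverse kind of exchange, returning to a fluorinated phenyl ring. Compound 2 also carries 3,5-difluorophenyl on its sulfonyl sulfur and gives a low number, but it differs from compound 3 in a second place as well, so its value alone cannot be read as a measure of this change. A modest fall, roughly undoing the rise seen from compound 1 to compound 3, is therefore the expectation. The expected step is a 2.6-fold lower number from compound 3 to compound 4 (0.41 log units; beyond the scatter). Compound 4 is estimated at 1.6 mL/min, with a range from 0.6 mL/min to 3.8 mL/min.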

Compound 4, intrinsic clearance in a liver preparation (reported as CLH), per the amount of preparation that the assay uses: 1.51 mL/min
Beside the measured number, compound 4's estimate is 1.1-fold (0.03 log units) above it; the measured number falls inside the stated range.
By their numbers in this assay, from the lowest: compound 2; then compounds 4 and 1 (each within the scatter of the next); then compound 3.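

The new compound shows that the rise seen with 3,4-dimethylphenyl on the sulfonyl sulfur is not a one-off against a single fluorinated ring: with 4-methoxyphenyl kept in the other place, 3,5-difluorophenyl in place of 3,4-dimethylphenyl gives a 2.7-fold lower number from compound 3 to compound 4 (0.44 log units; beyond the scatter) in this assay. The number of fluoro groups on that ring makes no readable difference here, since fluoro in place of hydrogen on an aromatic carbon gives a 1.3-fold lower number from compound 1 to compound 4 (0.10 log units; within the scatter), so the two fluorinated rings cannot be told apart in this assay. Going by these compounds alone, it also gives the first clean look at the other place on the core: with 3,5-difluorophenyl held constant, 4-methoxyphenyl in place of 3-chlorophenyl on an aromatic carbon gives a 6.9-fold higher number from compound 2 to compound 4 (0.84 log units; beyond the scatter), a step larger in size than either step at the sulfonyl sulfur.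

No measurement is available here that explains why either change moves the number. From the compounds shown here alone, it also remains open how this assay would respond to a group of a different kind on the sulfonyl sulfur, such as an amine or a longer carbon chain, in place of the phenyl rings compared so far.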